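The source may hold more compounds than are shown below. What is called first, only, known or untested is meant among the compounds shown, and "the series" means these compounds.

The shared core can be seen in compound 1, `CC[C@H](c1ccc(C(=O)O)c(Oc2cccc(Cl)c2)c1OC)N1CCC[C@H](n2cc(C)c(=O)[nH]c2=O)C1`, which in an ADME assay on the whole organism (strain Wistar) for pharmacokinetics, with Rattus norvegicus as the target, given by the intravenous route (a higher number here means faster removal of the compound, a lower number slower removal), gives 84 mL/min/kg. Going by the values given here, compound 2, `CCC[C@H](c1ccc(C(=O)O)c(Oc2cccc(Cl)c2)c1OC)N1CCC[C@H](n2cc(C)c(=O)[nH]c2=O)C1`, carries a propyl chain in place of the ethyl chain of compound 1, but in this assay compound 2 gives "not determined" (no result reported), so there is no single number on which compound 2 can be placed; the only measured point is compound 1.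

Compound 3, `CCC[C@H](c1ccc(C(=O)O)c(Oc2cccc(Cl)c2)c1F)N1CCC[C@H](n2cc(C)c(=O)[nH]c2=O)C1`, has not yet been measured. It differs from compound 2 in one place: fluoro in place of methoxy on an aromatic carbon. Among the compounds with values here, with no measured step to lean on, the expectation for compound 3 in this assay is a change of moderate size at most, in no firm direction, and quite possibly none beyond the usual scatter. Resting on compound 1 and its 84 mL/min/kg, compound 3 is expected to give about 75 mL/min/kg, within a range from 35 mL/min/kg to 150 mL/min/kg.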

Compound 3, clearance: 64 mL/min/kg
Compound 3: the middle estimate sits 1.2-fold (0.07 log units) above what was measured; measured number inside the range.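

Going by these compounds alone, compound 2 has no single number in this assay, so no step to compound 3 can be read. On these data alone, what the swap from methoxy to fluoro does on its own to clearance stays open, and no evidence here bears on the result of compound 3.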